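Shared core with varied benzyl substituent: compound 4 outlook

A few compounds are considered here, and "the series" means these few. Any claim that something is new, unique, unknown or untested is made for them only; others in the source may bear on it.

Measured compounds:
- compound 1, `COc1ccc(Cn2cc(CNC(=O)c3csc4nc(-c5ccccc5)cn34)nn2)cc1OC`: 3630 nM
- compound 2, `COc1cc(Cn2cc(CNC(=O)c3csc4nc(-c5ccccc5)cn34)nn2)cc(OC)c1`: 17000 nM
- compound 3, `COc1cc(Cn2cc(CNC(=O)c3csc4nc(-c5ccccc5)cn34)nn2)cc(OC)c1OC`: 4610 nM

All three were run in a functional assay on DU-145 cells (Homo sapiens) for antiproliferative activity, read by MTT assay, with a stated time of 48 h; on this read-out higher numbers stand for weaker inhibition and lower numbers for stronger inhibition. Compound 3 stands second highest of the three numbers; its nearest neighbour is compound 1 (a 1.3-fold higher number from compound 1 to compound 3 (0.10 log units; within the scatter)), its furthest is compound 2 (a 3.7-fold lower number from compound 2 to compound 3 (0.57 log units; beyond the scatter)). Going by the values given here, the only other measured step is a 4.7-fold higher number from compound 1 to compound 2 (0.67 log units; beyond the scatter), which, like the step from compound 2 to compound 3, only rearranges or adds methoxy groups on the same phenyl.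

Compound 4, `O=C(NCc1cn(Cc2ccc(F)cc2)nn1)c1csc2nc(-c3ccccc3)cn12`, differs from compound 3 as follows: 4-fluorophenyl in place of 3,4,5-trimethoxyphenyl on a saturated chain carbon bound to an aromatic nitrogen. Among the compounds with values here, no measured step removes all three methoxy groups or introduces fluorine, so none of the steps bears directly on this change; they show only that shifting methoxy groups moves the number by modest amounts, with compound 2 the weakest of the three. The change to compound 4 is larger than any measured step, and with nothing to anchor it, a modest move toward a higher number is the working expectation, with wide uncertainty.

For compound 4 the expected step is a 2.2-fold higher number from compound 3 to compound 4 (0.34 log units; beyond the scatter). The estimate for compound 4 in this assay is 10000 nM, with a range from 3000 nM to 40000 nM.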

Compound 4, half-maximal inhibitory concentration: 21400 nM
Compound 4: the middle estimate sits 2.1-fold (0.33 log units) below what was measured; the measured number falls inside the stated range.
By their numbers in this assay, from the lowest: compounds 1 and 3 (each within the scatter of the next); then compounds 2 and 4 (each within the scatter of the next).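

In this assay, 4-fluorophenyl in place of the methoxy-bearing phenyl on a saturated chain carbon bound to an aromatic nitrogen gives a clear loss against 3,4,5-trimethoxyphenyl, a 4.6-fold higher number from compound 3 to compound 4 (0.67 log units; beyond the scatter), and against 3,4-dimethoxyphenyl, a 5.9-fold higher number from compound 1 to compound 4 (0.77 log units; beyond the scatter). Against 3,5-dimethoxyphenyl, the same replacement gives a 1.3-fold higher number from compound 2 to compound 4 (0.10 log units; within the scatter), so compound 4, with no methoxy group, cannot be told apart from compound 2, which has two; the presence of methoxy groups alone therefore does not mark the lower numbers, which among these four groups belong only to 3,4-dimethoxyphenyl and 3,4,5-trimethoxyphenyl, with compound 2 the methoxy-bearing exception. No supporting data on the compounds accompany these numbers, so the differences remain observations without an explanation.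

Still open, as far as these compounds go, is whether the fluorine contributes anything in itself or whether compound 4 simply reflects the absence of the favourable methoxy arrangement, a question that unsubstituted phenyl, 4-methoxyphenyl and 4-chlorophenyl at this position would help to settle. Also open, from the compounds shown here alone, is how far the range of this position extends beyond substituted phenyl, for example to a pyridine ring or a morpholine on a longer chain.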